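The source may report more compounds than this note shows. Statements on the series, on what has been measured and on what is new or still open speak of the compounds shown alone.

Measured compounds: compound 1 `NS(=O)(=O)c1ccccc1-c1cnc(C(=O)CCCCCCc2ccccc2)o1` gives 1500 nM in an assay (Rattus norvegicus) for inhibition of Fatty-acid amide hydrolase 1 (Homo sapiens); a higher number here means a weaker inhibitor, a lower number a stronger inhibitor; compound 2 `O=C(CCCCCCc1ccccc1)c1ncc(-c2ccc([N+](=O)[O-])cc2)o1` gives 50 nM in this assay.

Compound 2 holds the lowest number of the two, and its gap to compound 1 lies beyond the scatter. Compound 3 `O=C(CCCCCCc1ccccc1)c1ncc(-c2ncccn2)o1` differs from compound 2 by one change: pyrimidin-2-yl in place of 4-nitrophenyl on an aromatic carbon. For the measured compounds named here, no measured pair shows this change, so its size is a matter of expectation. The account expects a modest move toward a lower number, possibly no larger than the scatter itself, as the step of a 2.5-fold lower number from compound 2 to compound 3 (0.40 log units; beyond the scatter) states. Compound 3 is therefore estimated at 20 nM in this assay, with a range from 5 nM to 80 nM.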

Compound 3, inhibition constant: 5.3 nM
Compound 3: middle estimate off by 3.8-fold (0.58 log units), on the high side; measured number inside the range.
By their numbers in this assay, from the lowest: compound 3; then compound 2; then compound 1.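

On the aromatic carbon next to the ring oxygen, pyrimidin-2-yl in place of 4-nitrophenyl gives a 9.4-fold lower number from compound 2 to compound 3 (0.97 log units; beyond the scatter) in this assay. This position therefore accepts a six-membered aromatic ring with 2 hetero atoms, and the entering group, although it has fewer heavy atoms than the one it replaces, does not lose ground. Nothing measured here accounts for this gain.

The compounds shown leave open how phenyl or pyridin-2-yl would compare on this carbon. They therefore cannot settle whether the gain follows from the ring nitrogens of pyrimidin-2-yl or from the departure of the nitro group.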